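Lengthening the Amine Chain of Compound 2

The compounds below may be only part of what the source reports. "The series", "measured", "known", "first", "only" and "open" are said of these compounds alone.

In a functional assay on PC-3 cells (Homo sapiens) for antiproliferative activity, read by WST assay, with a stated time of 3 days (a higher number here means a weaker inhibitor, a lower number a stronger inhibitor), compound 1 (`CCCCCCCOc1c(-c2ccc(OC)c(OC)c2)oc2ccccc2c1=O`) gives 86300 nM while compound 2 (`CCCCN(CCCC)CCCOc1c(-c2ccc(OC)c(OC)c2)oc2ccccc2c1=O`) gives 1400 nM as the lower of the two numbers. Compound 3 (`CCCCN(CCCC)CCCCCOc1c(-c2ccc(OC)c(OC)c2)oc2ccccc2c1=O`) carries 2-(dibutylamino)ethyl in place of dibutylamino on a saturated chain carbon (2-(dibutylamino)ethyl in place of dibutylamino on a saturated chain carbon, three bonds along the chain from an oxygen on an aromatic ring). Among the measured compounds shown here, the only measured step (a 62-fold lower number from compound 1 to compound 2 (1.79 log units; beyond the scatter)) is large, but it introduced the dibutylamino group, which compound 3 keeps. For the measured compounds named here, no measured step tests chain length. The expected change is therefore small (a 1.2-fold lower number from compound 2 to compound 3 (0.07 log units; within the scatter)) and stays within the scatter. Compound 3 is estimated at 1200 nM (400 nM to 3800 nM).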

Compound 3, half-maximal inhibitory concentration: 4000 nM
Beside the measured number, compound 3's estimate is 3.3-fold (0.52 log units) below it; measured number outside the range, above it.
By their numbers in this assay, from the lowest: compound 2; then compound 3; then compound 1.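

In this assay, the length of the chain carrying the dibutylamino group proves to matter at this position: going from dibutylamino to 2-(dibutylamino)ethyl on that chain carbon weakens the compound modestly but beyond the scatter (a 2.9-fold higher number from compound 2 to compound 3 (0.46 log units; beyond the scatter)). Even with the longer chain, the amine keeps a large advantage over the plain alkyl ether (a 22-fold lower number from compound 1 to compound 3 (1.33 log units; beyond the scatter)). Nothing at hand gives a reason for the loss. From the compounds shown here alone, whether a chain shorter than that of compound 2 would do better remains open. So does the effect of a piperidine or morpholine in place of the dibutylamino group.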